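Lengthening the Linker Between Ether Oxygen and Piperidine

This account rests on a few compounds, and the source may have more. Where it says the series, first, only, none or still open, it means among the compounds named here.

Within the data shown here, compound 2 `COc1cc2oc(-c3ccccc3)cc(=O)c2c(O)c1OCCCN1CCCCC1` gives the higher of the two numbers measured so far, 22300 nM in a functional assay on HepG2 cells (Homo sapiens) for antiproliferative activity, read by MTT assay, with a stated time of 48 h; a higher number here means a weaker inhibitor, a lower number a stronger inhibitor. Among the measured compounds shown here, its nearest neighbour, compound 1 `O=c1cc(-c2ccccc2)oc2cc(OCc3ccccc3)c(OCCCN3CCCCC3)c(O)c12`, gives 2200 nM in this assay, and the only measured step is a 10-fold higher number from compound 1 to compound 2 (1.01 log units; beyond the scatter). Compound 3 `COc1cc2oc(-c3ccccc3)cc(=O)c2c(O)c1OCCCCN1CCCCC1` differs from compound 2 by (piperidin-1-yl)methyl in place of piperidin-1-yl on a saturated chain carbon, three bonds along the chain from an oxygen on an aromatic ring. That measured step concerns a different part of the molecule and does not bear on this chain change, so nothing measured speaks for a shift in either direction. The expectation is therefore a step within the scatter, a 1.1-fold lower number from compound 2 to compound 3 (0.05 log units; within the scatter), for compound 3. Compound 3 is estimated at 20000 nM, within a range from 8000 nM to 50000 nM.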

Compound 3, half-maximal inhibitory concentration: 21000 nM
Compound 3: the middle estimate sits 1.1-fold (0.02 log units) below what was measured; low and high end bracket the measured number.
By their numbers in this assay, from the lowest: compound 1; then compounds 3 and 2 (each within the scatter of the next).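

The chain now has a measured step of its own: with (piperidin-1-yl)methyl in place of piperidin-1-yl, the result is a 1.1-fold lower number from compound 2 to compound 3 (0.03 log units; within the scatter), so this assay does not separate these two chain lengths. The large step seen so far, a 10-fold higher number from compound 1 to compound 2 (1.01 log units; beyond the scatter), belongs to the hydrogen-for-phenyl change and not to this chain. No measurement at hand bears on the reason for this result.

As far as these compounds go, whether a shorter 2-(piperidin-1-yl)ethyl chain or a longer 5-(piperidin-1-yl)pentyl chain would read the same remains open. So does the effect of a morpholine in place of the piperidine.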